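Carbamate chain extension on the shared core

This account rests on a few compounds, and the source may have more. Where it says the series, first, only, none or still open, it means among the compounds named here.

Measured so far:
Compound 1 `COC(=O)N1CCC(Oc2ncnc3c2CCN3c2ccc(S(C)(=O)=O)cc2F)CC1`: in a functional assay on CHO-K1 cells for agonist activity at Glucose-dependent insulinotropic receptor (Homo sapiens), read by a luciferase reporter, with a stated time of 5 h (a lower number here means that less compound is needed, a higher number that more compound is needed for the effect), compound 1 gives 316 nM.
Compound 2 `CCOC(=O)N1CCC(Oc2ncnc3c2CCN3c2ccc(S(C)(=O)=O)cc2F)CC1`: in this assay compound 2 gives 251 nM.

Compound 2 holds the lower of the two numbers, but the step of a 1.3-fold lower number from compound 1 to compound 2 (0.10 log units; within the scatter) does not separate them. Compound 3 `CC(C)COC(=O)N1CCC(Oc2ncnc3c2CCN3c2ccc(S(C)(=O)=O)cc2F)CC1` is not yet measured; it differs from compound 2 by isopropyl in place of methyl on a saturated chain carbon bound to an oxygen next to a carbonyl group. Going by the values given here, the one step that bears on it, the chain growth from compound 1 to compound 2, was small, so for compound 3 a step of a 1.1-fold lower number from compound 2 to compound 3 (0.06 log units; within the scatter) is expected in this assay, with no direction resolved. Compound 3 is estimated at 220 nM, range 80 nM to 600 nM.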

Compound 3, half-maximal effective concentration: 25.1 nM
Compound 3: middle estimate off by 8.8-fold (0.94 log units), on the high side; measured number below the stated range.
By their numbers in this assay, from the lowest: compound 3; then compounds 2 and 1 (each within the scatter of the next).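

In this assay this position is not insensitive to chain change: isopropyl in place of methyl on a saturated chain carbon bound to an oxygen next to a carbonyl group gives a 10-fold lower number from compound 2 to compound 3 (1.00 log units; beyond the scatter) and so moves beyond the scatter, which the step between compound 1 and compound 2 did not. Isopropyl in place of hydrogen at the same place gives a 13-fold lower number from compound 1 to compound 3 (1.10 log units; beyond the scatter) as the overall span. No measurement shown accounts for this drop.

As far as these compounds go, whether it follows the branching or the chain length stays open, since a straight butyl chain is absent from these compounds. Also open, from the compounds shown here alone, is whether a larger group, such as neopentyl or benzyl, lowers the number further.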